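This account rests on a few compounds, and the source may have more. Where it says the series, first, only, none or still open, it means among the compounds named here.

Series notes, cytotoxicity in a functional assay on U-937 cells (Homo sapiens) for cytotoxicity, read by MTT assay, with a stated time of 3 days; a higher number here means a weaker inhibitor, a lower number a stronger inhibitor.

Compound 1 `N#Cc1c(Cl)nc(SCc2nc3ccccc3[nH]2)nc1-c1ccccc1` gives 4.46 nM in this assay and stands highest of the three numbers measured, though its nearest neighbour and its furthest both lie within the usual scatter of it. Compound 2 `N#Cc1c(NN)nc(SCc2nc3ccccc3[nH]2)nc1-c1ccccc1` gives 3.9 nM; compound 3 `CCNc1nc(SCc2nc3ccccc3[nH]2)nc(-c2ccccc2)c1C#N` gives 2.63 nM. The step of a 1.1-fold lower number from compound 1 to compound 2 (0.06 log units; within the scatter) and the step of a 1.7-fold lower number from compound 1 to compound 3 (0.23 log units; within the scatter) are both within the scatter, as is the step of a 1.5-fold lower number from compound 2 to compound 3 (0.17 log units; within the scatter).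

Compound 4 `N#Cc1c(Nc2ccccn2)nc(SCc2nc3ccccc3[nH]2)nc1-c1ccccc1` has not yet been measured. Relative to compound 1 the change is (pyridin-2-yl)amino in place of chloro on an aromatic carbon. Within the data shown here, the steps that bear on it are those from compound 1 to compound 2 and from compound 1 to compound 3, since each also replaces the chloro on that aromatic carbon with a group bound through nitrogen; neither moved the number beyond the scatter. The (pyridin-2-yl)amino group is larger than either aminoamino or ethylamino, so the comparison is not exact, but nothing in the measured steps suggests a move of any particular direction.

The expectation is therefore a step of a 1.3-fold lower number from compound 1 to compound 4 (0.11 log units; within the scatter), that is, no change beyond the scatter. Compound 4 is estimated at 3.5 nM, with a range from 1.2 nM to 10 nM.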

Compound 4, half-maximal inhibitory concentration: 2.55 nM
Beside the measured number, compound 4's estimate is 1.4-fold (0.14 log units) above it; the measured number falls inside the stated range.
By their numbers in this assay, from the lowest: compounds 4, 3, 2 and 1 (each within the scatter of the next).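

In this assay the aromatic carbon ortho to a cyano group accepts a (pyridin-2-yl)amino group, which brings a six-membered aromatic ring to a place that had held only chloro, aminoamino and ethylamino, and the change gives a 1.7-fold lower number from compound 1 to compound 4 (0.24 log units; within the scatter) with no shift that can be read. On the nitrogen itself, the aromatic substituent cannot be told apart from the smaller ones: pyridin-2-yl in place of ethyl gives a 1.0-fold lower number from compound 3 to compound 4 (0.01 log units; within the scatter) and pyridin-2-yl in place of amino gives a 1.5-fold lower number from compound 2 to compound 4 (0.18 log units; within the scatter) in this series. Across these four compounds, then, the added ring and the larger size of the entering group leave the cytotoxicity number where it was, so this position has so far shown no sensitivity to the group it carries.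

Still open, on these data alone, is whether that holds for a group of another kind at this carbon, such as a carboxylic acid, a methoxy group or a morpholine ring bound through its nitrogen. Nothing available explains why the numbers stay together across these groups.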